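This account rests on a few compounds, and the source may have more. Where it says the series, first, only, none or still open, it means among the compounds named here.

Working notes on the sulfonamide series. Compound 1 `O=S(=O)(Nc1ccc2oc(-c3ccccc3)nc2c1)c1cccc(C(F)(F)F)c1`, compound 2 `Cc1cccc(S(=O)(=O)Nc2ccc3oc(-c4ccccc4)nc3c2)c1` and compound 3 `O=S(=O)(Nc1ccc2oc(-c3ccccc3)nc2c1)c1ccc(O)cc1` share one core and differ only in the ring on the sulfonyl sulfur. In an ADME assay on HEK293 cells (Homo sapiens) for cytotoxicity, read by resazurin assay, with a stated time of 48 h (a lower number here means that less compound is tolerated, a higher number that more compound is tolerated), compound 1 gives no number but a limit of the assay, > 100000 nM. Within the data shown here, compound 2 is the only member with a measured value in this assay, 69000 nM. Compound 3 again reaches only the limit of the assay in this assay, > 100000 nM. Among the measured compounds shown here, both steps so far, an at least 1.4-fold lower number from compound 1 to compound 2 (0.16 log units; that floor lies within the scatter) and an at least 1.4-fold higher number from compound 2 to compound 3 (0.16 log units; that floor lies within the scatter), are therefore bounded by a limit, and their floors lie within the scatter; the picture is framed by the limit of > 100000 nM in this assay, at which 2 of the 3 values shown sit.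

Compound 3 thus stands at the top of the range seen, at the limit, with only compound 2 below it. Compound 4 `O=S(=O)(Nc1ccc2oc(-c3ccccc3)nc2c1)c1cccc(O)c1` differs from compound 3 by 3-hydroxyphenyl in place of 4-hydroxyphenyl on a sulfonyl sulfur. For the measured compounds named here, no measured step moves a hydroxyl around the ring on the sulfonyl sulfur, so the nearest guide is the pair of limits on compound 1 and compound 3 together with the modest step of an at least 1.4-fold higher number from compound 2 to compound 3 (0.16 log units; that floor lies within the scatter). No change beyond the scatter is expected, a number no higher from compound 3 to compound 4 (the limit leaves the size open). Compound 4 is estimated at 100000 nM in this assay, between 50000 nM and 200000 nM, most likely reported again as a limit.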

Compound 4, half-maximal cytotoxic concentration: > 100000 nM
Compound 4 was reported as a limit; the forecaster's own chance of this, stated with the estimate: 70%; the middle value sits exactly at the limit.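

In this assay compound 4 gives > 100000 nM as a limit of the assay, so 3-hydroxyphenyl on the sulfonyl sulfur ends at the same limit as 4-hydroxyphenyl, and neither of the two hydroxyphenyl groups yields a measured number. Compared with the only measured member, the series gives an at least 1.4-fold higher number from compound 2 to compound 4 (0.16 log units; that floor lies within the scatter) and so compound 2 is still not shown to differ from any other member beyond the scatter, while the steps from compound 3 to compound 4 and from compound 1 to compound 4 cannot be read, as both ends of each are limits. The exchange of the two hydroxyphenyl groups therefore has no readable size, and the series now sits mostly at one ceiling: the limit of > 100000 nM in this assay, at which 3 of the 4 values shown sit.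

Still open, as far as these compounds go, is how far past the limit compound 1, compound 3 and compound 4 lie, and whether any group on the sulfonyl sulfur gives a number clearly lower than that of compound 2. An amine or a carboxylic acid in place of the hydroxyl, or a longer chain on that ring, would show whether this position can move the read-out beyond the scatter.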